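Moving the Chlorine on the Chlorobenzyl Arm

The source may hold more compounds than are shown below. What is called first, only, known or untested is meant among the compounds shown, and "the series" means these compounds.

Measured compounds:
compound 1, `COc1ccc(C2N=C(SCc3ccc(Cl)cc3)NC(C)=C2C(=O)Nc2ccc(F)cc2)cc1OC`, 20.1%
compound 2, `CC1=C(C(=O)Nc2ccc(Br)cc2)C(c2ccc(Cl)cc2Cl)N=C(SCc2ccccc2)N1`, 13.4%
compound 3, `CC1=C(C(=O)Nc2ccc(Br)cc2)C(c2ccc(Cl)cc2Cl)N=C(SCc2ccccc2Cl)N1`, 22.2%

In a functional assay on the whole organism (artery, strain albino) with Rattus norvegicus as the target, with a stated time of 180 min, at a dose of 10 mg/kg by the oral route (on this read-out higher numbers stand for more inhibition at the one dose given (going by the name of the read-out) and lower numbers for less inhibition), compound 1 gives 20.1%, compound 2 gives 13.4% and compound 3 gives 22.2%. The number for compound 3 is the highest of the three, yet its gaps to compound 1 and to compound 2 both lie within the scatter, so no order among the three can be read from them. Going by the values given here, the one single-point change measured so far is a number 8.8 percentage points higher from compound 2 to compound 3 (within the scatter), which is within the scatter.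

Compound 4, `CC1=C(C(=O)Nc2ccc(Br)cc2)C(c2ccc(Cl)cc2Cl)N=C(SCc2cccc(Cl)c2)N1`, shares every atom with compound 3 but joins them differently: 3-chlorophenyl in place of 2-chlorophenyl on a saturated chain carbon bound to a sulfur. Among the compounds with values here, the step from compound 2 to compound 3 touched the same chlorobenzyl group and stayed within the scatter, and that is the only measured step that bears on this change. Nothing seen here suggests that relocating the chlorine on that ring should move the read-out beyond the scatter in either direction. Compound 4 is therefore expected to show 20%, with a plausible range from 8% to 32%. The expected step is a number 2.2 percentage points lower from compound 3 to compound 4 (within the scatter), essentially none beyond the scatter.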

Compound 4, a percentage reported as inhibition, in the whole organism at one dose (the size of the read-out at that dose, not a potency): 11.9%
Compound 4: the middle estimate sits 8.1 percentage points above what was measured; low and high end bracket the measured number.
By their numbers in this assay, from the lowest: compounds 4, 2, 1 and 3 (each within the scatter of the next, the first and the last beyond it).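

In this assay, going by these compounds alone, moving the chlorine produces the first step on this arm that passes the scatter, a number 10.3 percentage points lower from compound 3 to compound 4 (beyond the scatter), so 2-chlorobenzyl and 3-chlorobenzyl on this saturated chain carbon bound to a sulfur are not interchangeable, although the step is only modest. Neither chlorine stands apart from the plain benzyl arm of compound 2: a number 1.5 percentage points lower from compound 2 to compound 4 (within the scatter) and a number 8.8 percentage points higher from compound 2 to compound 3 (within the scatter) are both printed as within the scatter, and they run in opposite directions, so the only separation lies between the two chloro compounds themselves. Nothing available here explains why the read-out responds to this relocation.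

The compounds shown leave open whether a methoxy group, an amine or a carboxylic acid on this benzyl ring, or a longer chain between the sulfur and the ring, would separate from the plain benzyl arm of compound 2. They also leave open whether the gap between the two chloro compounds would hold at other doses, since each number is a read-out at one dose and not a potency.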